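The source may hold more compounds than are shown below. What is called first, only, known or untested is meant among the compounds shown, and "the series" means these compounds.

Compound 1 `CC(O)(COc1ccc(C#N)cc1)C(=O)Nc1ccc(S(F)(F)(F)(F)F)cc1` and compound 2 `CC(O)(COc1ccc(C#N)cc1C(F)(F)F)C(=O)Nc1ccc(S(F)(F)(F)(F)F)cc1` share one core. In a functional assay on DU-145 cells (Homo sapiens) for antiproliferative activity, read by propidium iodide staining, with a stated time of 96 h (a lower number here means a stronger inhibitor, a higher number a weaker inhibitor), compound 1 gives 32200 nM, and compound 2 gives 21200 nM. The change between them is trifluoromethyl in place of hydrogen on an aromatic carbon, and it made a 1.5-fold lower number from compound 1 to compound 2 (0.18 log units; within the scatter). Compound 3 `CC(O)(COc1cccc(C(F)(F)F)c1)C(=O)Nc1cccc(S(F)(F)(F)(F)F)c1` has a different core; the difference between the two cores is not broken down here. In this assay compound 3 gives 31700 nM. Compound 4 `CC(O)(COc1cc(C(F)(F)F)cc(C(F)(F)F)c1)C(=O)Nc1cccc(S(F)(F)(F)(F)F)c1` has not yet been measured; it differs from compound 3 by trifluoromethyl in place of hydrogen on an aromatic carbon. This is the same kind of change as from compound 1 to compound 2, but the entering group sits meta to a large group and meta to a trifluoromethyl group, rather than ortho to a large group and meta to a cyano group. The expectation for compound 4 rests on the step of a 1.5-fold lower number from compound 1 to compound 2 (0.18 log units; within the scatter) and on compound 3 at 31700 nM. Compound 4 is thus expected to make a step of a 1.4-fold lower number from compound 3 to compound 4 (0.14 log units; within the scatter). Compound 4 is estimated at 23000 nM in this assay, with a range from 9000 nM to 60000 nM.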

Compound 4, half-maximal inhibitory concentration: 9300 nM
Beside the measured number, compound 4's estimate is 2.5-fold (0.39 log units) above it; measured number inside the range.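

In this assay, trifluoromethyl in place of hydrogen on an aromatic carbon gave a 3.4-fold lower number from compound 3 to compound 4 (0.53 log units; beyond the scatter). Among these compounds, only this step lies beyond the scatter, but the gap between it and the earlier step does not: the same change on two cores in this assay, a 1.5-fold lower number (0.18 log units; within the scatter) from compound 1 to compound 2 and a 3.4-fold lower number (0.53 log units; beyond the scatter) from compound 3 to compound 4, 2.2-fold (0.35 log units) apart, within the scatter of two such steps. Moving the change from one core to the other is therefore not shown to alter its effect, yet two pairs cannot establish that the step has one fixed size or that it would hold on other cores in this series.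

The compounds shown leave open whether a different group in that place, such as chlorine, a methoxy group or an amine, would give a comparable step. They also leave open how a second trifluoromethyl group would act on the core of compound 1.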